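One More Fluoro on Compound 1

The source may hold more compounds than are shown below. What is called first, only, known or untested is meant among the compounds shown, and "the series" means these compounds.

In a physicochemical assay for lipophilicity (a lower number here means a more polar compound, a higher number a more lipophilic compound), compound 1 (`Fc1ccccc1C1=NC(c2ccccc2)CO1`) gives 3.51 and compound 2 (`Cc1ccccc1C1=NC(c2ccccc2)CO1`) gives 3.68 on the same scale, two values within the scatter of each other. Compound 3 (`Fc1cccc(F)c1C1=NC(c2ccccc2)CO1`) carries fluoro in place of hydrogen on an aromatic carbon and has not yet been measured. Within the data shown here, the only measured step (a number 0.17 log units higher from compound 1 to compound 2 (within the scatter)) puts methyl in place of fluoro, a different change, so it serves only as a loose guide. A small rise is expected (a number 0.09 log units higher from compound 1 to compound 3 (within the scatter)) and no step beyond the scatter. For compound 3 the estimated value is 3.6 with an expected range from 3.25 to 3.95 in this measurement.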

Compound 3, partition coefficient: 3.01
Compound 3: middle estimate off by 0.59 log units, on the high side; the whole stated range lies above it.
By their numbers in this assay, from the lowest: compound 3; then compounds 1 and 2 (each within the scatter of the next).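

Fluoro in place of hydrogen on an aromatic carbon, ortho to a large group and meta to a fluoro group, gives the first step beyond the scatter in this assay (a number 0.50 log units lower from compound 1 to compound 3 (beyond the scatter)). So this position is not neutral to a change of just one heavy atom, and the number can move downward here. No measurement at hand accounts for the drop.

From the compounds shown here alone, whether other groups at this position would also lower the number remains open, for example chloro, methoxy or an amine. Also open, going by these compounds, is whether fluoro elsewhere on this ring would give a similar step.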